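Phenyl Added to the Methyl of Compound 2

The compounds below may be only part of what the source reports. "The series", "measured", "known", "first", "only" and "open" are said of these compounds alone.

Compound 2 `Cn1c(=O)n(C2OC(CO)[C@@H](O)[C@H]2O)c2nc(N)nc(O)c21` carries a methyl group on an aromatic nitrogen of the shared core. Among the compounds with values here, in a functional assay (B cells) with Mus musculus as the target (a higher number here means that more compound is needed for the effect, a lower number that less compound is needed), compound 2 gives 10 uM, standing at one end of the two numbers recorded, yet separated from its only neighbour by less than the scatter. That neighbour, compound 1 `N#Cc1ccc(Cn2c(=O)n(C3OC(CO)[C@@H](O)[C@H]3O)c3nc(N)nc(O)c32)cc1`, in this assay gives 15 uM. Within the data shown here, the single measured step between them, a 1.5-fold lower number from compound 1 to compound 2 (0.18 log units; within the scatter), shows that taking the 4-cyanophenyl off that chain carbon left the number essentially where it was.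

Compound 3 `Nc1nc(O)c2c(n1)n(C1OC(CO)[C@@H](O)[C@H]1O)c(=O)n2Cc1ccccc1` is the unmeasured partner: phenyl in place of hydrogen on a saturated chain carbon bound to an aromatic nitrogen. The same difference, cut one bond further out, reads methyl to benzyl. Among the measured compounds shown here, this change is the mirror of the one measured step, which removed a substituted phenyl from the very same carbon and moved the number only within the scatter. Compound 3 is therefore expected to show a step of a 1.2-fold higher number from compound 2 to compound 3 (0.08 log units; within the scatter), inside the scatter. The estimate for compound 3 in this assay is 12 uM, within the range 5 uM to 30 uM.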

Compound 3, concentration for half-maximal effect: 6 uM
For compound 3 the middle estimate is 2.0-fold (0.30 log units) above the measured one; the measured number falls inside the stated range.
By their numbers in this assay, from the lowest: compounds 3, 2 and 1 (each within the scatter of the next, the first and the last beyond it).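

Putting phenyl in place of hydrogen on the saturated chain carbon bound to an aromatic nitrogen gives a 1.7-fold lower number from compound 2 to compound 3 (0.22 log units; within the scatter) in this assay and so adds a second step at this carbon that stays inside the scatter, this time with an unsubstituted ring. Within the data shown here, the new information lies further out on that ring, where hydrogen in place of cyano on an aromatic carbon gives a 2.5-fold lower number from compound 1 to compound 3 (0.40 log units; beyond the scatter) and is the only step among the three compounds to pass beyond the scatter, though only modestly, so the substituent on the ring can be told apart in this read-out even though neither phenyl-bearing compound can be told apart from the methyl compound 2. No measurement is available that explains either step.

As far as these compounds go, what an amine or a carboxylic acid in place of that cyano would do to the number in this assay remains open. So does the outcome of a longer chain, such as propyl, in place of the methyl of compound 2, and with only these three compounds the reading of this position rests on very few steps.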